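From 4-fluorophenoxy to (4-fluorophenyl)carbonyl: compound 3 awaits measurement

The compounds below may be only part of what the source reports. "The series", "measured", "known", "first", "only" and "open" are said of these compounds alone.

Compound 1 `CC(C)(C)c1[nH]cnc1/C=c1\[nH]c(=O)/c(=C/c2cccc(C(=O)c3ccc(F)cc3)c2)[nH]c1=O`: 0.6 nM
Compound 2 `O=c1[nH]/c(=C\c2nc[nH]c2C2CC2)c(=O)[nH]/c1=C\c1cccc(Oc2ccc(F)cc2)c1`: 9.4 nM

Among the compounds with values here, in a functional assay on BXPC-3 cells (Homo sapiens) for cytotoxicity, read by MTT assay, with a stated time of 72 h (on this read-out lower numbers stand for stronger inhibition and higher numbers for weaker inhibition), only two compounds have a number so far. Compound 2 gives 9.4 nM and compound 1 gives 0.6 nM. The gap between these two numbers lies beyond the scatter, and compound 2, with the higher number, is the weaker inhibitor of the pair. Compound 3 `O=C(c1ccc(F)cc1)c1cccc(/C=c2\[nH]c(=O)/c(=C/c3nc[nH]c3C3CC3)[nH]c2=O)c1` departs from compound 2 at one place: (4-fluorophenyl)carbonyl in place of 4-fluorophenoxy on an aromatic carbon. Within the data shown here, no measured pair shows this change alone, so any forecast is indirect. The incoming group is also carried by compound 1 at 0.6 nM, but that compound differs from compound 3 elsewhere too, so only part of the gap between the two measured compounds can be expected to carry over. A modest move toward lower numbers is expected in this assay, perhaps not far beyond the scatter. The estimated change is a 3.1-fold lower number from compound 2 to compound 3 (0.50 log units; beyond the scatter). For compound 3 the estimated value is 3 nM, with an expected range of 0.8 nM to 11 nM.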

Compound 3, half-maximal inhibitory concentration: 1.4 nM
Compound 3: the middle estimate sits 2.1-fold (0.33 log units) above what was measured, within the range that was stated.
By their numbers in this assay, from the lowest: compound 1; then compound 3; then compound 2.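

In this assay, within the data shown here, the exchange of 4-fluorophenoxy for (4-fluorophenyl)carbonyl on this aromatic carbon gives a 6.7-fold lower number from compound 2 to compound 3 (0.83 log units; beyond the scatter), the first direct reading of this change with the rest of the molecule held constant. The second single change, cyclopropyl in place of tert-butyl on an aromatic carbon, gives a 2.3-fold higher number from compound 1 to compound 3 (0.37 log units; beyond the scatter), so the gap between compound 1 and compound 2 now divides into two separate steps, with the larger one belonging to the (4-fluorophenyl)carbonyl exchange. No supporting measurement is available to explain either step.

As far as these compounds go, it remains open whether the two steps would hold independently of each other, since that would require the pairing of tert-butyl with 4-fluorophenoxy on the same shared core. Also open, from the compounds shown here alone, is how a methylene or an amine in place of the carbonyl, joining the same two aromatic rings, would compare in this assay, and whether a chlorine or a methoxy group in place of the fluorine would keep the number as low as that of compound 3.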